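The compounds below may be only part of what the source reports. "The series", "measured", "known", "first", "only" and "open" are said of these compounds alone.

Measured compounds:
- compound 1, `Cn1c(-c2ccc(NC(=O)CCl)cc2)nc(-c2ccccc2)c1-c1ccccc1`, gives 14.4% in a functional assay on HT-29 cells (Homo sapiens) for cytotoxicity, read by MTT assay, with a stated time of 24 h, tested at 1.6 ug/mL; a lower number here means a weaker effect, a higher number a stronger effect of the compound at the concentration tested
- compound 2, `Cc1ccc2oc(SCC(=O)Nc3ccc(-c4nc(-c5ccccc5)c(-c5ccccc5)n4C)cc3)nc2c1`, gives 15.5% in this assay
- compound 3, `Cn1nnnc1SCC(=O)Nc1ccc(-c2nc(-c3ccccc3)c(-c3ccccc3)n2C)cc1`, gives 49.8% in this assay

Among these three, compound 1 stands lowest in this assay. Its nearest neighbour is compound 2, with the step of a number 1.1 percentage points higher from compound 1 to compound 2 (within the scatter), which is within the usual scatter, so the two cannot be told apart. The furthest is compound 3, with the step of a number 35.4 percentage points higher from compound 1 to compound 3 (beyond the scatter), a large rise beyond the scatter.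

The new compound 4, `CN(C)/C=C/N1CCN(CC(=O)Nc2ccc(-c3nc(-c4ccccc4)c(-c4ccccc4)n3C)cc2)CC1`, has not yet been measured. It differs from compound 1 as follows: 4-(2-(dimethylamino)ethenyl)piperazin-1-yl in place of chloro on a saturated chain carbon bound to a carbonyl carbon.

Two of the measured steps bear on this change. Both also swap the chloro at the same saturated chain carbon for a larger group: the step of a number 1.1 percentage points higher from compound 1 to compound 2 (within the scatter) stayed within the scatter, while the step of a number 35.4 percentage points higher from compound 1 to compound 3 (beyond the scatter) was large. The step of a number 34.3 percentage points higher from compound 2 to compound 3 (beyond the scatter) shows that the identity of the entering group matters greatly. The group entering in compound 4 is unlike either, so the direction is uncertain; a moderate rise is expected, with wide bounds.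

For compound 4 the estimated step is a number 10.6 percentage points higher from compound 1 to compound 4 (beyond the scatter), giving an expected value of 25%, between 8% and 50%.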

Compound 4, a percentage reported as activity, at one concentration (the size of the read-out at that concentration, not a potency): 8%
Estimate against measurement, compound 4: 17 percentage points above; the measured number falls inside the stated range.
By their numbers in this assay, from the lowest: compounds 4, 1 and 2 (each within the scatter of the next); then compound 3.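

In this assay, replacing the chloro with 4-(2-(dimethylamino)ethenyl)piperazin-1-yl gives a number 6.4 percentage points lower from compound 1 to compound 4 (within the scatter), so this much larger group cannot be told apart from the single chlorine atom it replaces. Its comparison with the (5-methyl-1,3-benzoxazol-2-yl)sulfanyl group gives a number 7.5 percentage points lower from compound 2 to compound 4 (within the scatter), which places compound 1, compound 2 and compound 4 together within the scatter. Only the (1-methyl-1H-tetrazol-5-yl)sulfanyl group stands apart, with a number 41.8 percentage points lower from compound 3 to compound 4 (beyond the scatter), so at this saturated chain carbon bound to a carbonyl carbon, a larger group in place of chloro does not by itself bring a rise: of the three larger groups shown, only the one in compound 3 does.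

No measurement available here explains why compound 3 differs from the other three compounds. From the compounds shown here alone, it also remains open how a plain piperazine without the 2-(dimethylamino)ethenyl part, a simple dimethylamino group or a carboxylic acid would read at this carbon, and whether a 1-methyl-1H-imidazol-2-yl group on the sulfur would match the value of compound 3.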